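The source may hold more compounds than are shown below. What is called first, only, known or untested is meant among the compounds shown, and "the series" means these compounds.

Within the data shown here, in a functional assay on BV-2 cells (Mus musculus) for inhibition, read by Griess assay, with stated times of 30 min and 24 h (on this read-out lower numbers stand for stronger inhibition and higher numbers for weaker inhibition), compound 1 `CC(C)CC(=O)O[C@@H]1OC=C(CO[C@@H]2O[C@H](CO)[C@@H](O)[C@H](O)[C@H]2OC(=O)/C=C/c2ccc(O)cc2)[C@H]2CC[C@](O)(CO)[C@@H]12` gives 45500 nM, the higher of the two numbers measured so far. Among the measured compounds shown here, its only measured neighbour is compound 2 `CC(C)CC(=O)O[C@@H]1OC=C(CO[C@@H]2O[C@H](CO)[C@@H](O)[C@H](O)[C@H]2OC(=O)/C=C\c2ccc(O)cc2)[C@H]2CC[C@](O)(CO)[C@@H]12`, which in this assay gives 900 nM; the change is a 51-fold lower number from compound 1 to compound 2 (1.70 log units; beyond the scatter). That step rests on (the fact that compounds 1 and 2 differ only in the configuration as drawn), so it concerns only how a double bond is drawn and says nothing about the ester chain.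

Compound 3 `CCC(C)C(=O)O[C@@H]1OC=C(CO[C@@H]2O[C@H](CO)[C@@H](O)[C@H](O)[C@H]2OC(=O)/C=C/c2ccc(O)cc2)[C@H]2CC[C@](O)(CO)[C@@H]12` has not yet been measured. It differs from compound 1 by sec-butyl in place of isobutyl on a carbonyl carbon, the two having the same atoms joined differently. For the measured compounds named here, no measured pair tests such a rearrangement of the chain, and the one measured step, which turns on the drawn configuration of a double bond elsewhere in the molecule, does not bear on it. With nothing to push the number either way, the expected change in this assay is a 1.0-fold lower number from compound 1 to compound 3 (0.00 log units; within the scatter), that is, none beyond the scatter. Going by the values given here, compound 3 is therefore estimated at 45000 nM, with a range from 12000 nM to 170000 nM in this assay, acknowledging that the range is wide since no measured step guides it.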

Compound 3, half-maximal inhibitory concentration: 1250 nM
For compound 3 the middle estimate is 36-fold (1.56 log units) above the measured one, outside the stated range (below it).
By their numbers in this assay, from the lowest: compounds 2 and 3 (each within the scatter of the next); then compound 1.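

The ester chain on this carbonyl carbon is not a silent part of the molecule: in this assay, replacing isobutyl with sec-butyl brings a 36-fold lower number from compound 1 to compound 3 (1.56 log units; beyond the scatter), a large step for so small an edit. The two chains hold the same atoms joined differently, so here the read-out responds to how the carbons of the chain are connected, and not only to which atoms are present, while the rest of compound 3 stays as in compound 1. Among these compounds, nothing in the information at hand bears on why this rearrangement moves the number so far.

On these data alone, it remains open whether the same swap would move the number at all in the compound that carries the double bond drawn Z, as compound 2 does, and whether the two changes would add up or overlap. Also unresolved is how much variation this carbonyl carbon tolerates: a tert-butyl group, a longer chain such as hexyl, or a chain ending in an amine or a carboxylic acid would each show whether the effect is particular to sec-butyl or extends to other groups.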